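The compounds below may be only part of what the source reports. "The series", "measured", "known", "first", "only" and "open" are said of these compounds alone.

Measured so far in a functional assay on isolated protein for inhibition of Glucose-dependent insulinotropic receptor (Homo sapiens), read by HTRF and cAMP accumulation; on this read-out higher numbers stand for an effect only at larger amounts of compound and lower numbers for an effect already at smaller amounts:
compound 1 `Cc1nc(S(C)(=O)=O)ccc1Oc1ncnc(OC2CCN(C(=O)O[C@@H](C)CF)CC2)c1F` gives 186 nM
compound 2 `Cc1nc(S(C)(=O)=O)ccc1Oc1ncnc(OC2CCN(C(=O)OC3COC3)CC2)c1F` gives 326 nM

Going by the values given here, compound 2 carries the higher of the two numbers, yet its only neighbour, compound 1, stands within the scatter of it, so no order between the two can be claimed. Among the compounds with values here, the one measured step, a 1.8-fold higher number from compound 1 to compound 2 (0.24 log units; within the scatter), concerns the group on the carbamate oxygen and did not move the read-out beyond the scatter.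

Compound 3 `Cc1nc(S(C)(=O)=O)ccc1Oc1ncnc(OC2CCN(C(=O)OC3(C(F)(F)F)COC3)CC2)c1F` keeps the core and the carbamate of compound 2 and differs only by trifluoromethyl in place of hydrogen on a saturated ring carbon. Within the data shown here, no measured step touches a substituent on this four-membered ring, so the only guidance is that the one change at the carbamate oxygen, from compound 1 to compound 2, stayed within the scatter. On that basis no step beyond the scatter is expected for compound 3, its estimated shift being a 1.0-fold lower number from compound 2 to compound 3 (0.01 log units; within the scatter).

Compound 3 is expected to give about 320 nM in this assay, with a likely range of 120 nM to 850 nM.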

Compound 3, half-maximal effective concentration: 29.3 nM
The estimate for compound 3 lay 11-fold (1.04 log units) above the measured number; measured number below the stated range.
By their numbers in this assay, from the lowest: compound 3; then compounds 1 and 2 (each within the scatter of the next).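

In this assay, going by these compounds alone, the group on the carbamate oxygen can move the read-out beyond the scatter: replacing hydrogen with trifluoromethyl on the saturated ring carbon gives an 11-fold lower number from compound 2 to compound 3 (1.05 log units; beyond the scatter), the first such step. The 3-(trifluoromethyl)oxetan-3-yl group also separates from the 1-(fluoromethyl)ethyl group, with a 6.3-fold lower number from compound 1 to compound 3 (0.80 log units; beyond the scatter), so compound 3 stands apart from both earlier compounds. Nothing available accounts for these steps.

Still open, going by these compounds, is whether this step is specific to trifluoromethyl or would also appear with methyl, a nitrile or an amine on the same ring carbon. Also open, on these data alone, is whether trifluoromethyl gives a similar step on a cyclobutyl ring, which lacks the ring oxygen, or on the 1-(fluoromethyl)ethyl chain.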